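Triazole nitrogen substituent swap in the biphenyl diol series

The source may hold more compounds than are shown below. What is called first, only, known or untested is meant among the compounds shown, and "the series" means these compounds.

Of the compounds shown here, two have been measured in a functional assay on HCT-116 cells (Homo sapiens) for inhibition, read by MTT assay, with a stated time of 72 h; on this read-out lower numbers stand for stronger inhibition of growth and higher numbers for weaker inhibition of growth. Compound 1, `COC1=C(C)C(=O)C(CCCCCCCCCCn2cc(C[C@H](O)COCCOC[C@@H](O)Cc3ccc(-c4ccccc4)cc3)nn2)=C(C)C1=O`, carries a long chain to a quinone on the triazole and gives 4000 nM in this assay. Compound 2, `O[C@H](COCCOC[C@@H](O)Cc1cn(-c2cccs2)nn1)Cc1ccc(-c2ccccc2)cc1`, has the same biphenyl diol ether arm but a thiophen-2-yl group directly on the aromatic nitrogen of the triazole; in this assay compound 2 gives 33400 nM, the highest of the two numbers, and the gap to compound 1 lies beyond the usual scatter. Among the measured compounds shown here, no step between measured compounds differing in one place exists, so no single-change step can be drawn from these two numbers.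

Compound 3, `O[C@H](COCCOC[C@@H](O)Cc1cn(-c2ccc3c(c2)OCCO3)nn1)Cc1ccc(-c2ccccc2)cc1`, differs from compound 2 in one place: 2,3-dihydro-1,4-benzodioxin-6-yl in place of thiophen-2-yl on an aromatic nitrogen. Nothing measured in the series speaks to this particular exchange. The expectation for the step from compound 2 to compound 3 is therefore none beyond the scatter, written as a 1.1-fold lower number from compound 2 to compound 3 (0.05 log units; within the scatter). Compound 3 is estimated at 30000 nM in this assay, with a range from 10000 nM to 90000 nM.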

Compound 3, concentration for 50% growth inhibition: 16500 nM
Compound 3: the middle estimate sits 1.8-fold (0.26 log units) above what was measured; measured number inside the range.
By their numbers in this assay, from the lowest: compound 1; then compound 3; then compound 2.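

In this assay, among the compounds shown here, 2,3-dihydro-1,4-benzodioxin-6-yl in place of thiophen-2-yl on the aromatic nitrogen gives a 2.0-fold lower number from compound 2 to compound 3 (0.31 log units; beyond the scatter) as the first single-place step, and it is a modest one. The aromatic nitrogen of the five-membered aromatic ring with 3 nitrogen therefore shows some sensitivity to the group it bears: here a group of 10 heavy atoms, with one six-membered aromatic ring and one six-membered non-aromatic ring, replaces a five-membered aromatic ring of 5 heavy atoms without loss of growth inhibition. No independent measurement bears on what lies behind this step.

The compounds shown leave open whether the step follows the six-membered aromatic ring alone or needs the non-aromatic ring with its two oxygens, and a plain phenyl group on the same nitrogen would separate the two. Also open, from the compounds shown here alone, is how the long chain to a quinone in compound 1 would read against either group, since compound 1 differs from both compound 2 and compound 3 in more than one place.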